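This account rests on a few compounds, and the source may have more. Where it says the series, first, only, none or still open, it means among the compounds named here.

Among the measured compounds shown here, compound 1 `OCCC(NC1CCN(CCCc2c[nH]c3ccc(-n4cnnc4)cc23)CC1)c1ccccc1` is the most efficacious of the three compounds measured so far: in a functional assay on CHO cells for activation of 5-hydroxytryptamine receptor 1D (Homo sapiens), read by GTPgammaS binding (on this read-out lower numbers stand for smaller maximal responses and higher numbers for larger maximal responses), compound 1 gives 100%. The two analogues that vary the group on the amine nitrogen sit lower. Compound 2 `NC(=O)OC[C@H](NC1CCN(CCCc2c[nH]c3ccc(-n4cnnc4)cc23)CC1)c1ccccc1` gives 73% in this assay, and compound 3 `CC(=O)Nc1ccc(CNC2CCN(CCCc3c[nH]c4ccc(-n5cnnc5)cc34)CC2)cc1` gives 75%. Both changes away from compound 1 cost efficacy: a number 27 percentage points lower from compound 1 to compound 2 (beyond the scatter) and a number 25 percentage points lower from compound 1 to compound 3 (beyond the scatter), while a number 2 percentage points higher from compound 2 to compound 3 (within the scatter).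

Compound 4 `CC(C)=CCN(C)C1CCN(CCCc2c[nH]c3ccc(-n4cnnc4)cc23)CC1` has not yet been measured. Relative to compound 1 the change is methyl(3-methylbut-2-en-1-yl)amino in place of (3-hydroxy-1-phenylpropyl)amino on a saturated ring carbon. The two measured steps from compound 1 both replaced the same group on the amine and both gave modest drops, so a drop is expected here too, and since the aromatic ring is also lost the uncertainty is wider. The expected step is a number 32 percentage points lower from compound 1 to compound 4 (beyond the scatter). For compound 4 the estimate in this assay is 68%, with a likely range from 42% to 95%.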

Compound 4, largest response reached (reported as efficacy), in percent of the reference or control that the assay uses: 115%
Compound 4: middle estimate off by 47 percentage points, on the low side, outside the stated range (above it).
By their numbers in this assay, from the lowest: compounds 2 and 3 (each within the scatter of the next); then compound 1; then compound 4.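

The change at this saturated ring carbon need not cost maximal response: in this assay the swap to methyl(3-methylbut-2-en-1-yl)amino goes the other way, with a number 15 percentage points higher from compound 1 to compound 4 (beyond the scatter) and not the drop seen with both earlier replacements of (3-hydroxy-1-phenylpropyl)amino. Compound 4 thus reaches this response with no six-membered aromatic ring, no oxygen and no hydrogen-bond donor in the entering group, so none of these features of compound 1 is required for it. No available evidence bears on the reason for this rise.

Compound 4 brings in the methyl on the nitrogen and the unsaturated chain together, and the compounds shown do not separate the two. Going by these compounds, whether a saturated 3-methylbutyl chain, a plain methylamino group or an N-methylbenzylamino group would give a similar response remains open.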